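Amide nitrogen substituent and liver-cell cytotoxicity in the series

The source may hold more compounds than are shown below. What is called first, only, known or untested is meant among the compounds shown, and "the series" means these compounds.

Compound 3 `CC(CSc1nnc(-c2ccncc2)s1)C(=O)Nc1ccc(Cl)cc1Cl` carries a 2,4-dichlorophenyl on the amide-type nitrogen. In an ADME assay on HepG2 cells (Homo sapiens) for cytotoxicity, with a stated time of 3 days (on this read-out lower numbers stand for higher toxicity in this test and higher numbers for lower toxicity in this test), compound 3 reaches only the limit of the assay, > 50000 nM, and no number. Compound 1 `CC(CSc1nnc(-c2ccncc2)s1)C(=O)NCc1ccccc1Cl`, with a 2-chlorobenzyl on the same nitrogen, likewise gives only the limit > 50000 nM in this assay. Compound 2 `CC(CSc1nnc(-c2ccncc2)s1)C(=O)Nc1c(Cl)cccc1Cl`, with a 2,6-dichlorophenyl there, also stops at the limit > 50000 nM. Hence (the limit of > 50000 nM in this assay, at which 3 of the 3 values shown sit), and the steps a step that the two limits leave unreadable from compound 1 to compound 2, a step that the two limits leave unreadable from compound 1 to compound 3 and a step that the two limits leave unreadable from compound 2 to compound 3 carry no readable size.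

Compound 4 `CC(CSc1nnc(-c2ccncc2)s1)C(=O)NCc1ccccc1` differs from compound 3 by benzyl in place of 2,4-dichlorophenyl on an amide-type nitrogen. Going by the values given here, no measured step gives the size of such a change, and all three measured compounds, compound 1 with its 2-chlorobenzyl among them, sit at the limit in this assay. Compound 4 is therefore expected to sit at the limit as well. The expected step is a step that the limit leaves unreadable from compound 3 to compound 4. For compound 4 the expected value in this assay is 80000 nM, within a range of 30000 nM to 300000 nM, a readable number being seen as unlikely.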

Compound 4, half-maximal cytotoxic concentration: > 50000 nM
Compound 4: a limit, no number (the forecaster's own chance of this, stated with the estimate: 85%); the middle value is on the limit's open side.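

Compound 4 joins compound 1, compound 2 and compound 3 in giving only a limit and no number, so no step among these compounds can be read: the limit of > 50000 nM in this assay, at which 4 of the 4 values shown sit.

The compounds shown leave open whether any substituent on the amide-type nitrogen would give a readable number in this assay.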